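Sulfonylquinoline series: chloro for methyl, two settings

A few compounds are considered here, and "the series" means these few. Any claim that something is new, unique, unknown or untested is made for them only; others in the source may bear on it.

Measured so far, in an assay on isolated protein for displacement of a labelled ligand from metabotropic glutamate receptor 5 (Homo sapiens), with a stated time of 60 min, tested at 1 uM; a lower number here means less inhibition, a higher number more inhibition at the concentration tested (going by the name of the read-out):
compound 1 `CC1CCN(c2c(S(=O)(=O)c3ccc(Cl)c(Cl)c3)cnc3ccc(Cl)cc23)CC1` gives 86%
compound 2 `Cc1ccc(S(=O)(=O)c2cnc3ccc(Cl)cc3c2N2CCC(C)CC2)cc1Cl` gives 81%
compound 3 `Cc1ccc2ncc(S(=O)(=O)c3ccc(C#N)cc3)c(N3CCC(C)CC3)c2c1` gives 55%

Compound 2 and compound 1 differ in one place only, (chloro in place of methyl on an aromatic carbon), and the step between them is a number 5 percentage points higher from compound 2 to compound 1 (within the scatter). Compound 3 stands lowest of the three numbers; the nearest of the others is compound 2, and the difference between the two cores of compound 3 and compound 2 is not broken down here.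

Compound 4 `CC1CCN(c2c(S(=O)(=O)c3ccc(C#N)cc3)cnc3ccc(Cl)cc23)CC1` is not yet measured. It differs from compound 3 by chloro in place of methyl on an aromatic carbon. This is the same kind of change as from compound 2 to compound 1, but not the same: there the chloro entered on a six-membered aromatic ring of carbon only, ortho to a chloro group and para to a large group, while here it enters on a ring that is part of a fused system of two rings, meta and para to a fused ring.

For compound 4 the step to expect is a number 5 percentage points higher from compound 3 to compound 4 (within the scatter), estimated to stay small because the earlier step of a number 5 percentage points higher from compound 2 to compound 1 (within the scatter) was within the scatter. For compound 4 the estimate in this assay is 60%, with a range from 45% to 75%.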

Compound 4, a percentage reported as inhibition, at one concentration (the size of the read-out at that concentration, not a potency): 31%
Estimate against measurement, compound 4: 29 percentage points above, outside the stated range (below it).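

In this assay, chloro in place of methyl on an aromatic carbon does not carry over from one core to another as a constant step: the same change on two cores in this assay, a number 5 percentage points higher (within the scatter) from compound 2 to compound 1 and a number 24 percentage points lower (beyond the scatter) from compound 3 to compound 4, 29 percentage points apart, beyond the scatter of two such steps On the core bearing 4-cyanophenyl on the sulfonyl sulfur, with the change on a ring that is part of a fused system of two rings, the result is a number 24 percentage points lower from compound 3 to compound 4 (beyond the scatter), while the replacements of the sulfonyl aryl group are larger, a number 50 percentage points lower from compound 2 to compound 4 (beyond the scatter) and a number 55 percentage points lower from compound 1 to compound 4 (beyond the scatter). This does not show what sets the two methyl-to-chloro steps apart, since the two pairs differ both in the ring that takes the change and in the rest of the structure, and two pairs at a single concentration give inhibition at that concentration, not potency.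

The compounds shown leave open how methyl and chloro compare on the fused ring when 3,4-dichlorophenyl or 3-chloro-4-methylphenyl sits on the sulfonyl sulfur, which would separate the effect of the ring from that of the sulfonyl aryl group. They also leave open how a carboxylic acid, an amide or a methoxy group would read in place of the nitrile of the 4-cyanophenyl group.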